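Longer tetrazole tether on a leukotriene receptor series

The compounds below may be only part of what the source reports. "The series", "measured", "known", "first", "only" and "open" are said of these compounds alone.

Measured compounds:
Compound 1 `CCCc1c(COc2ccc(C(=O)Cc3nnn[nH]3)cc2)ccc(C(C)=O)c1O` gives 24.1 mg/kg in an in vivo functional assay on the whole organism (Rattus norvegicus) with cysteinyl leukotriene receptor (Homo sapiens) as the target; a higher number here means that more compound is needed for the effect, a lower number that less compound is needed.
Compound 2 `CCCc1c(COc2ccc(C(=O)CCCC(=O)O)cc2)ccc(C(C)=O)c1O` gives 9.5 mg/kg in this assay.
Compound 3 `CCCc1c(COc2ccc(C(=O)CCCc3nnn[nH]3)cc2)ccc(C(C)=O)c1O` gives 7.2 mg/kg in this assay.

Compound 3 has the lowest number of the three. Its gap to compound 2 is small: a 1.3-fold lower number from compound 2 to compound 3 (0.12 log units; within the scatter). Its gap to compound 1 is larger: a 3.3-fold lower number from compound 1 to compound 3 (0.52 log units; beyond the scatter).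

Compound 4 `CCCc1c(COc2ccc(C(=O)CCCCCCc3nnn[nH]3)cc2)ccc(C(C)=O)c1O` is not yet measured. It differs from compound 3 in one place: 3-(1H-tetrazol-5-yl)propyl in place of 1H-tetrazol-5-yl on a saturated chain carbon, three bonds along the chain from a carbonyl carbon. The tetrazole ring is kept, and a longer saturated chain is placed between the carbonyl and the ring.

Going by the values given here, one measured step bears on this directly. Moving the tetrazole out by a short chain already gave a modest gain: a 3.3-fold lower number from compound 1 to compound 3 (0.52 log units; beyond the scatter). The step of a 2.5-fold lower number from compound 1 to compound 2 (0.40 log units; beyond the scatter) points the same way, with an acid in place of the ring. Nothing shows what happens when the chain is made longer still than in compound 3, so the expectation is a flat to slightly lower number, within or just beyond the scatter.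

Compound 4 is therefore expected to give about 5.5 mg/kg in this assay, with a likely range from 2 mg/kg to 15 mg/kg.

The expected step is a 1.3-fold lower number from compound 3 to compound 4 (0.12 log units; within the scatter).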

Compound 4, dose for half-maximal effect: 8.5 mg/kg
For compound 4 the middle estimate is 1.5-fold (0.19 log units) below the measured one, and the stated range covers the measured number.
By their numbers in this assay, from the lowest: compounds 3, 4 and 2 (each within the scatter of the next); then compound 1.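

Taken by itself, the change from 1H-tetrazol-5-yl to 3-(1H-tetrazol-5-yl)propyl at this place, on a saturated chain carbon three bonds along the chain from a carbonyl carbon, makes no difference that can be told from the scatter in this assay (a 1.2-fold higher number from compound 3 to compound 4 (0.07 log units; within the scatter)), so this position accepts a clearly longer saturated chain with the tetrazole ring kept at its end. The carboxylic acid and the tetrazole on the longer chain also cannot be told apart (a 1.1-fold lower number from compound 2 to compound 4 (0.05 log units; within the scatter)), while the advantage over the shortest tether in this set remains (a 2.8-fold lower number from compound 1 to compound 4 (0.45 log units; beyond the scatter)), which places the clear difference between the shortest chain and the two longer tetrazole chains, and none between those two. The data shown give no explanation for this levelling off.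

From the compounds shown here alone, it remains open whether a chain longer than that of compound 4 keeps the same level or finally loses it. A carboxylic acid on the longer chain of compound 4, or an ether oxygen or an amide within that chain, would test how much depends on the tetrazole ring and how much on a plain saturated chain.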